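From fluoro to bromo on compound 2

This account rests on a few compounds, and the source may have more. Where it says the series, first, only, none or still open, it means among the compounds named here.

In an ADME assay on Vero cells (Chlorocebus sabaeus) for cytotoxicity, read by CellTiter-Glo, with a stated time of 72 h (on this read-out higher numbers stand for lower toxicity in this test and lower numbers for higher toxicity in this test), compound 2 (`[O-][n+]1nc(NC2CCCC2)[n+]([O-])c2ccc(F)cc21`) gives 2.3 ug/mL as its reading. Compound 1 (`[O-][n+]1nc(NC2CC2)[n+]([O-])c2ccc(F)cc21`) gives 1.3 ug/mL on the same read-out, and a 1.8-fold higher number from compound 1 to compound 2 (0.25 log units; within the scatter) separates the two, so compound 2 stands level with compound 1. Compound 3 (`[O-][n+]1nc(NC2CCCCC2)[n+]([O-])c2ccc(F)cc21`) reads < 2.5 ug/mL and that is a limit of the assay, not a number. As a result, a step that the limit leaves unreadable from compound 1 to compound 3 and a step that the limit leaves unreadable from compound 2 to compound 3 offer no size to work with.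

Compound 4 (`[O-][n+]1nc(NC2CCCC2)[n+]([O-])c2ccc(Br)cc21`) carries bromo in place of fluoro on an aromatic carbon, on a six-membered aromatic ring of carbon only that is part of a fused or bridged system of two rings. For the measured compounds named here, no measured step touches that fluoro group, since all three change only the ring on the nitrogen, so the evidence is indirect. Resting on compound 2 at 2.3 ug/mL and on a 1.8-fold higher number from compound 1 to compound 2 (0.25 log units; within the scatter) as the only readable step, no step beyond the scatter is expected in this assay and no firm direction can be called. The expected step is a 1.2-fold lower number from compound 2 to compound 4 (0.06 log units; within the scatter) and it should stay inside the scatter. The value estimated for compound 4 is 2 ug/mL with 0.9 ug/mL to 4.5 ug/mL as the expected range.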

Compound 4, half-maximal cytotoxic concentration: 18 ug/mL
Beside the measured number, compound 4's estimate is 9.0-fold (0.95 log units) below it; the measured number lies above the stated range.
By their numbers in this assay, from the lowest: compounds 1 and 2 (each within the scatter of the next); then compound 4.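

In this assay, for the compounds shown here, bromo in place of fluoro on an aromatic carbon gives a 7.8-fold higher number from compound 2 to compound 4 (0.89 log units; beyond the scatter), the only readable step that lies beyond the scatter. Going by these compounds alone, the one readable change to the ring on the nitrogen, a 1.8-fold higher number from compound 1 to compound 2 (0.25 log units; within the scatter), stays within the scatter, so among the pairs that can be read, this aromatic carbon is the place where a single change shifts the reading towards lower toxicity in this test, though that rests on one pair alone. Nothing among the measurements shown bears on why this exchange of halogen moves the reading.

Compound 3 gives < 2.5 ug/mL, which is a limit of the assay and not a number, and the steps that involve it cannot be read. On these data alone, it remains open whether the step belongs to bromo itself or to the loss of fluoro, which chloro or an amine on the same aromatic carbon could separate, and whether it carries over to the cyclopropyl and cyclohexyl members.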